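A few compounds are considered here, and "the series" means these few. Any claim that something is new, unique, unknown or untested is made for them only; others in the source may bear on it.

Compound 2 `Cc1cc(C)cc(Cn2c(=O)cc(N)n(CC#N)c2=O)c1` was tested in an ADME assay on MT4 cells (Homo sapiens) for cytotoxicity, read by MTT assay, with a stated time of 4 days; on this read-out higher numbers stand for lower toxicity in this test and lower numbers for higher toxicity in this test. In this assay compound 2 reaches > 100000 nM, which is a limit of the assay rather than a measured number. Compound 1 `Cc1cc(C)cc(Cn2c(=O)cc(N=[N+]=[N-])n(Cc3ccccn3)c2=O)c1` in this assay likewise reaches > 100000 nM, again a limit. Every value shown so far stands at the limit of > 100000 nM in this assay, at which 2 of the 2 values shown sit. Compound 3 `Cc1cc(C)cc(Cn2c(=O)cc(N=[N+]=[N-])n(CC#N)c2=O)c1` is the compound still to be measured; it differs from compound 2 by azido in place of amino on an aromatic carbon. Compound 1 carries the same azido group. For compound 3 the expected change is a step that the limit leaves unreadable from compound 2 to compound 3, no step beyond the scatter, with an estimated value of 150000 nM, between 60000 nM and 400000 nM.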

Compound 3, half-maximal cytotoxic concentration: 60000 nM
For compound 3 the middle estimate is 2.5-fold (0.40 log units) above the measured one; low and high end bracket the measured number.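

In this assay, for the compounds shown here, compound 3 is the only one of the three compounds with a measured number rather than a limit, at 60000 nM. Azido in place of amino on the aromatic carbon gives an at least 1.6-fold lower number from compound 2 to compound 3 (0.22 log units; that floor lies within the scatter), and cyano in place of pyridin-2-yl on the chain carbon gives an at least 1.6-fold lower number from compound 1 to compound 3 (0.22 log units; that floor lies within the scatter). Both steps are floors only, because the true size stays hidden behind the limit: the limit of > 100000 nM in this assay, at which 2 of the 3 values shown sit.

Going by these compounds, the full size of either step remains open. Also open, on these data alone, is whether a methoxy group or a chlorine on this aromatic carbon would give a measured number in this assay.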